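Working notes: from compound 1 to compound 4

The compounds below may be only part of what the source reports. "The series", "measured", "known", "first", "only" and "open" are said of these compounds alone.

Measured in a functional assay on MCF7 cells (Homo sapiens) for antiproliferative activity, read by MTT assay, with a stated time of 48 h; a lower number here means a stronger inhibitor, a higher number a weaker inhibitor:
compound 1 `N=C(N)N/N=C(/C=C/c1ccc(Cl)cc1)c1ccccc1` gives 700 nM
compound 2 `N=C(N)N/N=C(/C=C/c1cccc([N+](=O)[O-])c1)c1ccccc1` gives 6500 nM
compound 3 `N=C(N)N/N=C(/C=C/c1ccccc1F)c1ccccc1` gives 3900 nM

Compound 1 has the lowest number of the three, and the values of compound 2 and compound 3 both lie beyond the scatter from it. Compound 4 `N=C(N)N/N=C(/C=C/c1ccccc1Br)c1ccccc1` is not yet measured. Its difference from compound 1 is 2-bromophenyl in place of 4-chlorophenyl on a double-bonded chain carbon bound to a double-bonded chain carbon, with 2-bromophenyl in place of 4-chlorophenyl on a double-bonded chain carbon bound to a double-bonded chain carbon. Among the measured compounds shown here, one measured step bears on this change: a 5.6-fold higher number from compound 1 to compound 3 (0.75 log units; beyond the scatter), a modest step that puts 2-fluorophenyl in the same place. For the measured compounds named here, no measured compound carries 2-bromophenyl itself, so that step is only a guide. On the evidence of compound 3 at 3900 nM, a step of similar size towards a higher number is expected in this assay. The estimated step is a 4.0-fold higher number from compound 1 to compound 4 (0.60 log units; beyond the scatter). For compound 4 the estimated value is 2800 nM, with an expected range of 1000 nM to 7000 nM.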

Compound 4, half-maximal inhibitory concentration: 4200 nM
Compound 4: the middle estimate sits 1.5-fold (0.18 log units) below what was measured; low and high end bracket the measured number.
By their numbers in this assay, from the lowest: compound 1; then compounds 3, 4 and 2 (each within the scatter of the next).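

In this assay, 2-bromophenyl in place of 4-chlorophenyl gives a 6.0-fold higher number from compound 1 to compound 4 (0.78 log units; beyond the scatter), so a second group at this place, a larger halogen than the fluoro of compound 3, also stands beyond the scatter from compound 1. Bromo in place of fluoro on an aromatic carbon gives a 1.1-fold higher number from compound 3 to compound 4 (0.03 log units; within the scatter), so exchanging these two halogens on the ring makes no difference beyond the scatter for this pair. No measured evidence accounts for either step.

A 2-chlorophenyl or a 4-bromophenyl group would separate the identity of the halogen from its place on the ring, and the compounds shown leave that separation open. From the compounds shown here alone, how a 2-methoxyphenyl or a 2-aminophenyl group would compare at this place also remains open.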